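Swapping an Aryl Arm for a Short Chain

This account rests on a few compounds, and the source may have more. Where it says the series, first, only, none or still open, it means among the compounds named here.

This small set of compounds shares one core and was tested in an ADME assay on MDBK cells (Bos taurus) for cytotoxicity; on this read-out lower numbers stand for higher toxicity in this test and higher numbers for lower toxicity in this test. Compound 1 `Fc1cccc(F)c1Cn1cccc2nc(-c3c(F)cccc3F)nc1-2` gives > 100000 nM in this assay, which is a limit of the test and not a number. Compound 2 `Cc1ccn(Cc2c(F)cccc2F)c2nc(-c3c(F)cccc3F)nc1-2` carries a methyl in place of hydrogen on an aromatic carbon; in this assay compound 2 gives > 100000 nM, again a limit. The step that the two limits leave unreadable from compound 1 to compound 2 has limits at both ends and so its size cannot be read. Compound 3 `Clc1ccccc1Cn1ccc2nc(-c3ccccc3)nc-2c1` gives > 100000 nM in this assay, also a limit. All three measured compounds thus stand at the same place, described by the limit of > 100000 nM in this assay, at which 3 of the 3 values shown sit.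

Compound 4 `CC(C)CCn1ccc2nc(-c3ccccc3)nc-2c1` differs from compound 3 by isobutyl in place of 2-chlorophenyl on a saturated chain carbon bound to an aromatic nitrogen. Among the compounds with values here, no measured step touches this kind of change, and the only step available, a step that the two limits leave unreadable from compound 1 to compound 2, is unreadable. Nothing in these numbers points toward a change beyond the scatter, and with every measured compound at the limit, compound 4 is expected to remain there as well. For compound 4 the expected step is a number no higher from compound 3 to compound 4 (the limit leaves the size open), none beyond the scatter. Compound 4 is therefore estimated at 100000 nM, in a range from 50000 nM to 300000 nM, and most likely reported again as a limit.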

Compound 4, half-maximal cytotoxic concentration: > 100000 nM
Compound 4 was reported as a limit; the forecaster's own chance of this, stated with the estimate: 85%; the middle value lies on the limit itself.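

Compound 4, like compound 3, is reported only as a limit in this assay, and the step between these two compounds cannot be read. All the compounds shown stand at one place: the limit of > 100000 nM in this assay, at which 4 of the 4 values shown sit.

What they leave open is whether any change to the shared core or its groups would bring a measurable toxicity in this assay.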